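The source may report more compounds than this note shows. Statements on the series, on what has been measured and on what is new or still open speak of the compounds shown alone.

Measured so far: compound 1 `Cc1ccc2snc(/N=C\c3ccccc3O)c2c1`, 2000 nM; compound 2 `COc1cccc(/C=N\c2nsc3ccccc23)c1O`, 2000 nM. Both values come from a functional assay on CCRF-CEM cells (Homo sapiens) for antiproliferative activity, read by MTT assay, with a stated time of 96 h; a lower number here means a stronger inhibitor, a higher number a weaker inhibitor. On these numbers compound 1 stands level with compound 2 at the digits given, the two lying within the scatter of each other, so nothing can be read between them. Compound 3 `Cc1ccc2snc(/N=C\c3ccccc3Cl)c2c1` has not yet been measured in this assay. It differs from compound 1 by chloro in place of hydroxy on an aromatic carbon. For the measured compounds named here, no measured step covers this change, so the expectation rests on compound 1 alone. From compound 1, the step is expected to be small, leaning toward weaker inhibition: a 1.5-fold higher number from compound 1 to compound 3 (0.18 log units; within the scatter). Compound 3 is therefore estimated at 3000 nM, within 800 nM to 12000 nM.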

Compound 3, half-maximal inhibitory concentration: 1500 nM
For compound 3 the middle estimate is 2.0-fold (0.30 log units) above the measured one; low and high end bracket the measured number.
By their numbers in this assay, from the lowest: compounds 3, 1 and 2 (each within the scatter of the next).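

In this assay, chloro in place of hydroxy on an aromatic carbon, ortho to a large group, gives a 1.3-fold lower number from compound 1 to compound 3 (0.12 log units; within the scatter). The hydroxy is therefore not needed at this position to hold the value at this level, and chloro serves there about as well. Nothing measured here bears on why the two groups read alike. As far as these compounds go, whether an amine, a carboxylic acid or a longer chain would be tolerated at this position remains open. So does whether chloro would read the same on the core of compound 2.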